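The compounds below may be only part of what the source reports. "The series", "measured", "known", "first", "only" and "open" are said of these compounds alone.

Compound 3 `CC(C)OC(=O)c1ccccc1C(=O)N1C[C@H](Oc2cc(C#N)ccn2)CC[C@H]1C` has the highest number of the three measured compounds in a functional assay on CHO-K1 cells for antagonist activity at Orexin/Hypocretin receptor type 1 (Homo sapiens), read by FLIPR and calcium flux (on this read-out lower numbers stand for stronger inhibition and higher numbers for weaker inhibition), giving 3300 nM. Compound 1 `C#Cc1ccnc(O[C@@H]2CC[C@@H](C)N(C(=O)c3ccccc3-n3nccn3)C2)c1` gives 240 nM and compound 2 `C[C@@H]1CC[C@@H](Oc2cc(Br)ccn2)CN1C(=O)c1ccccc1-n1nccn1` gives 380 nM; the step of a 1.6-fold higher number from compound 1 to compound 2 (0.20 log units; within the scatter) lies within the scatter. Compound 4 `C[C@@H]1CC[C@@H](Oc2cc(C#N)ccn2)CN1C(=O)c1ccccc1CC(F)(F)F` differs from compound 3 in one place: 2,2,2-trifluoroethyl in place of isopropoxycarbonyl on an aromatic carbon, on an aromatic carbon ortho to a large group. Within the data shown here, no measured step touches this part of the molecule, so the only guide is the gap between compound 3 and the two compounds that carry a different group at the same place. Compound 4 is therefore expected to land between them, with an estimated step of a 2.2-fold lower number from compound 3 to compound 4 (0.34 log units; beyond the scatter) and an expected value of 1500 nM, within a range of 300 nM to 8000 nM.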

Compound 4, half-maximal inhibitory concentration in the Orexin/Hypocretin receptor type 1 assay: > 10000 nM
Compound 4: no number, only a limit (the forecaster's own chance of this, stated with the estimate: 5%); middle value at least 6.6-fold (0.82 log units) from the limit.
By their numbers in the Orexin/Hypocretin receptor type 1 assay, from the lowest: compounds 1 and 2 (each within the scatter of the next); then compound 3. At a limit, above all of these: compound 4.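

In the Orexin/Hypocretin receptor type 1 assay, this first measured change at this place gives an at least 3.0-fold higher number from compound 3 to compound 4 (0.48 log units; beyond the scatter), so inhibition here depends on which group sits on this aromatic carbon. Compound 4 stands at a limit of the assay, not at a number: the limit of > 10000 nM in the Orexin/Hypocretin receptor type 1 assay, at which 1 of the 4 values shown sits.

In a physicochemical assay for lipophilicity, read by HPLC (on this read-out lower numbers stand for lower lipophilicity and higher numbers for higher lipophilicity), compound 3 gives 3.6 and compound 4 gives 3.6, so the loss of inhibition comes with no change in this read-out.

Going by these compounds, the full size of the loss stays open, since compound 4 has only a limit. The compounds shown also leave open how an amine or a carboxylic acid would behave at this place.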